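Swapping the aryl substituent on a piperidine amide antagonist

The source may hold more compounds than are shown below. What is called first, only, known or untested is meant among the compounds shown, and "the series" means these compounds.

Measured compounds:
- Compound 1, `CCCCCCN1CCC(C(=O)Nc2cc(Cl)c(N)cc2OC)CC1`: in a functional assay on the whole organism for antagonist activity, with Mus musculus as the target (on this read-out higher numbers stand for an effect only at larger amounts of compound and lower numbers for an effect already at smaller amounts), compound 1 gives only a limit, > 10 mg/kg.
- Compound 2, `COc1ccc(CN2CCC(C(=O)Nc3cc(Cl)c(N)cc3OC)CC2)cc1`: compound 2 gives 0.9 mg/kg.
- Compound 3, `COc1cc(N)c(Cl)cc1NC(=O)C1CCN(Cc2ccccc2)CC1`: compound 3 gives 0.5 mg/kg.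

Compound 2 stands highest of the two numbers that are not limits, with compound 3 nearest to it; that gap, a 1.8-fold lower number from compound 2 to compound 3 (0.26 log units; within the scatter), stays within the usual scatter, so the two cannot be told apart.

Compound 4, `COc1cc(N)c(Cl)cc1NC(=O)C1CCN(Cc2cccc(Cl)c2)CC1`, has not yet been measured. It differs from compound 2 by 3-chlorophenyl in place of 4-methoxyphenyl on a saturated chain carbon bound to an amine nitrogen in a ring.

Two steps show the aryl group matters against an alkyl chain: an at least 11-fold lower number from compound 1 to compound 2 (1.04 log units; beyond the scatter) and an at least 20-fold lower number from compound 1 to compound 3 (1.30 log units; beyond the scatter), both large. Within the data shown here, the only step that changes a group on that aryl ring, a 1.8-fold lower number from compound 2 to compound 3 (0.26 log units; within the scatter), stays within the scatter. Among the measured compounds shown here, no measured step covers 3-chlorophenyl itself, so for compound 4 the estimate is a step of a 1.5-fold lower number from compound 2 to compound 4 (0.18 log units; within the scatter), expected to stay within the scatter. Compound 4 is therefore estimated at 0.6 mg/kg, in the range 0.25 mg/kg to 1.5 mg/kg.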

Compound 4, dose for half-maximal effect: > 4 mg/kg
Compound 4 was reported as a limit; the forecaster's own chance of this, stated with the estimate: 5%; at least 6.6-fold (0.82 log units) between middle value and limit.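

Among these compounds, until now, the only change on the aryl ring, methoxy to hydrogen, had stayed within the scatter, but this position is not indifferent to what the ring carries. Replacing 4-methoxyphenyl with 3-chlorophenyl gives an at least 4.4-fold higher number from compound 2 to compound 4 (0.64 log units; beyond the scatter), and chloro in place of hydrogen on the aromatic carbon gives an at least 8.0-fold higher number from compound 3 to compound 4 (0.90 log units; beyond the scatter). The value of compound 4 is a limit of the assay, not a number: the limit of > 4 mg/kg in this assay, at which 1 of the 4 values shown sits.

In this assay, going by these compounds, how much larger a dose compound 4 needs therefore stays open, and the steps involving two limits, such as that from compound 1 to compound 4, cannot be read. Since 3-chlorophenyl is the only chlorinated aryl group shown, 4-chlorophenyl and 3-methoxyphenyl on the same chain carbon would help separate the effect of the chlorine from that of its place on the ring.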